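This account rests on a few compounds, and the source may have more. Where it says the series, first, only, none or still open, it means among the compounds named here.

Working notes, measured in an ADME assay on microsomes from liver (Canis lupus familiaris) for metabolic stability, with a stated time of 10 min, tested at 1 uM; on this read-out higher numbers stand for a more stable compound and lower numbers for a less stable compound:

- compound 1 `COc1c(-c2ccc(C(F)(F)F)cc2Cl)ccc2c1cnn2[C@@H](CC(C)C)c1ccc(C(=O)NCCC(=O)O)cc1`: 64%
- compound 2 `COc1c(-c2ccc(C(F)(F)F)cc2Cl)ccc2nn([C@@H](CC(C)C)c3ccc(C(=O)NCCC(=O)O)cc3)cc12`: 76%

Going by the values given here, of the two numbers so far, compound 2 holds the higher at 76%. Compound 1 at 64% lies lower, and that gap is beyond the usual scatter of repeated measurements.

The next compound to be read in this assay is compound 3 `COc1c(-c2ccc(C(F)(F)F)cc2Cl)ccc2nn([C@H](CC(C)C)c3ccc(C(=O)NCCC(=O)O)cc3)cc12`, the stereo partner of compound 2. The change is small on paper: the two compounds have the same atoms and bonds and differ only in configuration as drawn: 1 of 1 stereo elements differ; a stereocentre at a saturated chain carbon is drawn S in compound 2 and R in compound 3. Among the compounds with values here, nothing so far shows what inverting this stereocentre does, as no measured pair isolates such a change. Any expectation is therefore weakly anchored, and the range has to stay wide. The starting point is compound 2 at 76%. A small loss is expected rather than a gain, since this value is the higher of the two known, and most of the likely outcomes remain within the scatter. The expected change is a number 5 percentage points lower from compound 2 to compound 3 (within the scatter). For compound 3 the estimated value is 71%, with an expected range of 54% to 86%.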

Compound 3, percent of the compound remaining: 79%
The estimate for compound 3 lay 8 percentage points below the measured number; the range from low to high includes it.
By their numbers in this assay, from the lowest: compound 1; then compounds 2 and 3 (each within the scatter of the next).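

For the stereocentre at a saturated chain carbon, the series now has its first isolated reading: in this assay the pair gives a number 3 percentage points higher from compound 2 to compound 3 (within the scatter). Drawn S or R, this carbon therefore yields no difference that the read-out can separate from the usual scatter, so the configuration here does not decide the result for this pair. Any small difference hidden in that scatter could not be assigned to another part of the structure, because nothing else varies within the pair: the fact that compounds 2 and 3 differ only in the configuration as drawn

On these data alone, it remains open whether this lack of separation in this assay holds once the carboxylic acid is replaced by a tetrazole, or once the amide-linked chain that carries it is replaced by a longer chain, since both compounds of the pair share that same end of the molecule. Going by these compounds alone, also open is whether the two configurations stay within the scatter of each other when an amine is present on the shared core, as this single pair speaks only for the one set of groups it carries.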